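The source may hold more compounds than are shown below. What is called first, only, known or untested is meant among the compounds shown, and "the series" means these compounds.

Measured compounds in an assay on IMR-32 cells for displacement of a labelled ligand from corticotropin-releasing factor receptor 1 (Homo sapiens), read by scintillation counting, with a stated time of 2 h; on this read-out lower numbers stand for stronger inhibition and higher numbers for weaker inhibition:

compound 1 `CCc1nc(N(CC2CC2)CC2CC2)c(CC)nc1-c1ccc(Cl)cc1Cl`, 26 nM
compound 2 `CCc1nc(-c2ccc(Cl)cc2Cl)c(CC)nc1NC(C)CN(C)C`, 489 nM
compound 3 `CCc1nc(-c2ccc(OC(F)F)cc2Cl)c(OC)nc1NC(CC)CC`, 2.5 nM

Compound 2 gives the highest number of the three; compound 1 gives a lower number, and compound 3, which differs from compound 2 in several places at once, gives the lowest number of the set.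

Compound 4 `CCCN(CC1CC1)c1nc(CC)c(-c2ccc(Cl)cc2Cl)nc1CC` is not yet measured. Relative to compound 2 the change is (cyclopropylmethyl)(propyl)amino in place of (1-((dimethylamino)methyl)ethyl)amino on an aromatic carbon.

Within the data shown here, one measured step bears on this: a 19-fold higher number from compound 1 to compound 2 (1.27 log units; beyond the scatter), which exchanged a dialkylamino group carrying two cyclopropylmethyl chains for the basic (dimethylamino)methyl-bearing amine. Compound 4 reverses that exchange in kind, restoring a dialkylamino group with one cyclopropylmethyl and one propyl chain, so most of that step is expected to be recovered in this assay, giving a number close to that of compound 1. Because compound 1 gives 26 nM, compound 4 is expected to give a lower number than compound 2, by roughly a 14-fold lower number from compound 2 to compound 4 (1.15 log units; beyond the scatter). The estimate for compound 4 is 35 nM, with a range of 10 nM to 120 nM.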

Compound 4, inhibition constant: 19.2 nM
Compound 4: middle estimate off by 1.8-fold (0.26 log units), on the high side; low and high end bracket the measured number.
By their numbers in this assay, from the lowest: compound 3; then compounds 4 and 1 (each within the scatter of the next); then compound 2.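

In this assay, (cyclopropylmethyl)(propyl)amino in place of (1-((dimethylamino)methyl)ethyl)amino gives a 25-fold lower number from compound 2 to compound 4 (1.41 log units; beyond the scatter), so the return to the level of compound 1 does not depend on the bis(cyclopropylmethyl)amino group alone. Ethyl in place of cyclopropyl on the saturated chain gives a 1.4-fold lower number from compound 1 to compound 4 (0.13 log units; within the scatter), so the propyl and cyclopropylmethyl chains cannot be told apart at this position, and the second three-membered ring is not required to hold that level. No supporting data explain the large gap between these dialkylamino groups and the amine of compound 2.

From the compounds shown here alone, the step from compound 2 changes the dimethylamino end and the amine hydrogen together, so their separate contributions remain open. Also open, going by these compounds, is whether a longer chain such as butyl, or a morpholine, on this aromatic carbon would hold the same level.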